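The source may hold more compounds than are shown below. What is called first, only, known or untested is meant among the compounds shown, and "the series" means these compounds.

Three measured compounds share one core and differ only in the chain that hangs from the ring amine nitrogen: compound 1 `CCCCCN1CCC(NC(=O)c2cc(Cl)c(N)cc2OC)CC1`, compound 2 `COc1cc(N)c(Cl)cc1C(=O)NC1CCN(CCCCCO)CC1` and compound 3 `COc1cc(N)c(Cl)cc1C(=O)NC1CCN(CCCCCCCCS(=O)(=O)O)CC1`. In a functional assay on HEK293 cells for activation of 5-hydroxytryptamine receptor 4 (Homo sapiens), read by cAMP accumulation (a higher number here means a larger maximal response, a lower number a smaller maximal response), compound 1 gives > 100%, which is a limit of the assay and not a number. In this assay compound 2 gives > 100%, again a limit. In this assay compound 3 likewise gives > 100%, also a limit, and that is where compound 3 stands. Because of the limit of > 100% in this assay, at which 3 of the 3 values shown sit, none of the steps between these compounds can be sized: the step that the two limits leave unreadable from compound 1 to compound 2, the step that the two limits leave unreadable from compound 1 to compound 3 and the step that the two limits leave unreadable from compound 2 to compound 3 all stay unreadable. Compound 4 `COc1cc(N)c(Cl)cc1C(=O)NC1CCN(CCCCCN2CCN(S(C)(=O)=O)CC2)CC1` is not yet measured. It differs from compound 3 in one place: 4-(methylsulfonyl)piperazin-1-yl in place of 3-sulfopropyl on a saturated chain carbon, five bonds along the chain from an amine nitrogen in a ring. The measured steps bear on this change only in that every replacement at this place has so far left the response sitting at the limit, so they give no reason to expect a step of any readable size in this assay. The step of a number no higher from compound 3 to compound 4 (the limit leaves the size open) is therefore expected to be none beyond the scatter. Compound 4 is expected to give about 100%, within 85% and 115%.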

Compound 4, intrinsic activity: the largest response reached, in percent of the reference agonist's: > 100%
Compound 4 gave a limit, no number (the forecaster's own chance of this, stated with the estimate: 60%); the middle value sits exactly at the limit.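

In this assay compound 4 gives > 100% as a limit of the assay and not a number. Among these compounds, no step from compound 4 to compound 1, compound 2 or compound 3 can be read, because all four compounds sit at the same limit: the limit of > 100% in this assay, at which 4 of the 4 values shown sit. As far as these compounds go, whether the different chain groups change the maximal response in this assay at all, and by how much, stays open.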